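The source may report more compounds than this note shows. Statements on the series, on what has been measured and on what is new or still open speak of the compounds shown alone.

Measured so far
compound 1 `CC[C@]1(C(=O)O)CC[C@H](C(=O)N2CC[C@](c3ccc(C(F)(C(F)(F)F)C(F)(F)F)cc3)(S(=O)(=O)c3ccc(F)cc3)C2)CC1` gives "not determined" (no result reported)
compound 2 `C[C@]1(C(=O)N2CC[C@](c3ccc(C(F)(C(F)(F)F)C(F)(F)F)cc3)(S(=O)(=O)c3ccc(F)cc3)C2)CC[C@@H](C(=O)O)CC1` gives 100%
compound 3 `O=C1NC(=O)C2(CCC(C(=O)N3CC[C@](c4ccc(C(F)(C(F)(F)F)C(F)(F)F)cc4)(S(=O)(=O)c4ccc(F)cc4)C3)CC2)N1` gives 81%; 82% (2 entries)

All three entries come from an ADME assay on microsomes from liver (Mus musculus) for metabolic stability, with a stated time of 10 min (on this read-out higher numbers stand for a more stable compound and lower numbers for a less stable compound), and make up the whole of the data on this series. Among the measured compounds shown here, compound 2 at 100% holds the only single number and sits at the top of the read-out. Compound 1 has no number, and compound 3 lies lower, with its two entries in close agreement (see (the several entries of compound 3 in this assay, 81%; 82% (2 entries))).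

Next comes compound 4 `O=C([C@H]1CC[C@H](CO)CC1)N1CC[C@](c2ccc(C(F)(C(F)(F)F)C(F)(F)F)cc2)(S(=O)(=O)c2ccc(F)cc2)C1` which has no measurement yet. Its difference from compound 2 reads 4-(hydroxymethyl)cyclohexyl in place of 4-carboxy-1-methylcyclohexyl on a carbonyl carbon and the rest of the structure is shared. The carbonyl carbon stays on its amide-type nitrogen in a ring.

For the measured compounds named here, no measured step covers this change, so its size can only be judged from the values. A loss is expected rather than a gain. Compound 2 at 100% leaves no room upward, and compound 3 at 81%; 82% (2 entries) shows that another group on this carbonyl carbon can give a lower number. The expected step is a number 25 percentage points lower from compound 2 to compound 4 (beyond the scatter) and it is estimated to go downward, probably beyond the scatter. For compound 4 the estimated value is 75% with an expected range from 55% to 92% in this read-out.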

Compound 4, percent of the compound remaining: 63%
Compound 4: the middle estimate sits 12 percentage points above what was measured; the range from low to high includes it.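

In this assay, among the compounds shown here, this is the first measured step at the group on the carbonyl carbon, and it comes out as a number 37 percentage points lower from compound 2 to compound 4 (beyond the scatter). The shared core is unchanged and both groups hold one six-membered non-aromatic ring of carbon only, so that ring alone does not fix the number at this position; what else sits on the ring matters to the read-out. Compound 4 also gives a lower number than both entries of compound 3, so the hydantoin-bearing compound is no longer the low end of the numbers shown: the several entries of compound 3 in this assay, 81%; 82% (2 entries)

The change from 4-carboxy-1-methylcyclohexyl to 4-(hydroxymethyl)cyclohexyl alters two things at once, the carboxylic acid against the hydroxymethyl and the presence of the methyl, and the compounds shown do not separate these two parts of the step. Going by these compounds, a 4-carboxycyclohexyl group without the methyl, or a 4-(hydroxymethyl)-1-methylcyclohexyl group, would split the step into its two parts, and a primary amide or an aminomethyl group on the same ring remains open as well.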